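Adding a third methoxy to a weak growth inhibitor

This account rests on a few compounds, and the source may have more. Where it says the series, first, only, none or still open, it means among the compounds named here.

Measured in a functional assay on K562 cells (Homo sapiens) for inhibition, read by sulforhodamine B assay, with a stated time of 48 h; a higher number here means a weaker inhibitor of growth, a lower number a stronger inhibitor of growth:
- compound 1 `COc1ccc(/C=C/C2(C)C=CC(=O)O2)c(OC)c1`: > 1000000 nM, a limit
- compound 2 `COc1ccc(/C=C/C2(C)C=CC(=O)O2)cc1OC`: > 1000000 nM, a limit

Compound 2 stands at the limit of > 1000000 nM in this assay, at which 2 of the 2 values shown sit. For the measured compounds named here, neither compound has a number, so the two values cannot be ordered and no measured step is available.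

Compound 3 `COc1cc(OC)c(OC)cc1/C=C/C1(C)C=CC(=O)O1` has methoxy in place of hydrogen on an aromatic carbon of compound 2: methoxy in place of hydrogen on an aromatic carbon.

No step beyond the usual scatter is expected in this assay, in either direction. That expectation rests on compound 2 with > 1000000 nM, which is a limit. A report of compound 3 as a limit of the same kind is the likeliest outcome. The estimated change is a number no higher from compound 2 to compound 3 (the limit leaves the size open). For compound 3 the estimate is 1000000 nM, with an expected range of 300000 nM to 2000000 nM.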

Compound 3, concentration for total growth inhibition: > 1000000 nM
Compound 3 gave a limit, no number; the forecaster's own chance of this, stated with the estimate: 80%; the middle value sits exactly at the limit.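

No step can be read from compound 2 to compound 3 or from compound 1 to compound 3, because all three values are limits: the limit of > 1000000 nM in this assay, at which 3 of the 3 values shown sit.

The compounds shown leave open how strongly any of the three inhibits growth, and whether the added methoxy changes that at all.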